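Compound 4 in a series without a baseline

A few compounds are considered here, and "the series" means these few. Any claim that something is new, unique, unknown or untested is made for them only; others in the source may bear on it.

In a physicochemical assay for lipophilicity, measured as octanol-water partition, at pH 7.4 (on this read-out higher numbers stand for higher lipophilicity and lower numbers for lower lipophilicity), compound 1 (`Cc1cc(Cn2c(=O)[nH]c3c(N)nc(C(F)(F)F)cc32)no1`) gives 2.1 and compound 2 (`Cc1nc(Cn2c(=O)[nH]c3c(N)nc(C(F)(F)F)cc32)cs1`) gives 2.3. Compound 3 (`Nc1nc(C(F)(F)F)cc2c1[nH]c(=O)n2Cc1ccc(C(F)(F)F)nc1`) offers no number to start from: in this assay compound 3 stands as "not determined" (no result reported).

Compound 4 (`Nc1nc(C(F)(F)F)cc2c1[nH]c(=O)n2Cc1ccc(NCC2CC2)nc1`) has (cyclopropylmethyl)amino in place of trifluoromethyl on an aromatic carbon, next to the ring nitrogen and para to a large group: (cyclopropylmethyl)amino in place of trifluoromethyl on an aromatic carbon.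

Among the compounds with values here, the only measured step is a number 0.20 log units higher from compound 1 to compound 2 (within the scatter). Within the data shown here, it exchanges 5-methyl-1,2-oxazol-3-yl for 2-methyl-1,3-thiazol-4-yl, which is a different change from the one leading to compound 4, so it bears on this question only loosely. With no number for compound 3, neither a size nor a direction can be set for a step in this assay. The expectation therefore rests on the general level of the series, seen in compound 1 at 2.1 and compound 2 at 2.3. Among the measured compounds shown here, no measured step covers this exchange, so the range is kept wide.

Compound 4 is expected at 2.5, with an estimated range of 1.9 to 3.1.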

Compound 4, distribution coefficient: 3.2
For compound 4 the middle estimate is 0.70 log units below the measured one; the measured number lies above the stated range.
By their numbers in this assay, from the lowest: compounds 1 and 2 (each within the scatter of the next); then compound 4.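

Within the data shown here, compound 4 at 3.2 has no step to read from compound 3, which stands as "not determined" (no result reported) in this assay. The compounds shown leave open the size and direction of exchanging trifluoromethyl for (cyclopropylmethyl)amino. No measured evidence shown bears on the level of compound 4.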